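Hydroxyalkyl Chain Returns in Place of Phenyl

The compounds below may be only part of what the source reports. "The series", "measured", "known", "first", "only" and "open" are said of these compounds alone.

Two compounds of the series are measured. Compound 1 `CCCCC(O)c1ccc(CN(CCCCCCC(=O)O)S(C)(=O)=O)cc1` carries a 1-hydroxypentyl group on the aromatic ring of the benzyl unit; in an assay on HEK293 cells for inhibition of prostaglandin E2 receptor EP2 subtype (Rattus norvegicus) (on this read-out lower numbers stand for stronger inhibition and higher numbers for weaker inhibition), compound 1 gives 502 nM. Compound 2 `CS(=O)(=O)N(CCCCCCC(=O)O)Cc1ccc(-c2ccccc2)cc1` carries a phenyl at that position, and in this assay compound 2 gives 289 nM. Among the compounds with values here, this is the lowest of the two numbers so far, compound 1 being its nearest neighbour, but the gap is small: a 1.7-fold lower number from compound 1 to compound 2 (0.24 log units; within the scatter), so no order between the two can be claimed.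

Compound 3 `CCCCCC(O)c1ccc(CN(CCCCCCC(=O)O)S(C)(=O)=O)cc1` is not yet measured. Relative to compound 2 the change is 1-hydroxyhexyl in place of phenyl on an aromatic carbon. Within the data shown here, the only measured step that bears on this is the one between compound 1 and compound 2, which swapped a 1-hydroxypentyl for the phenyl and stayed within the scatter. Compound 3 runs that exchange in the opposite direction with a chain one carbon longer, so no step beyond the scatter is expected, if anything a slightly higher number. For compound 3 the expected value is 450 nM, in the range 200 nM to 1000 nM, corresponding to an expected step of a 1.6-fold higher number from compound 2 to compound 3 (0.19 log units; within the scatter).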

Compound 3, half-maximal inhibitory concentration: 93 nM
Beside the measured number, compound 3's estimate is 4.8-fold (0.68 log units) above it, outside the stated range (below it).
By their numbers in this assay, from the lowest: compound 3; then compounds 2 and 1 (each within the scatter of the next).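

In this assay the exchange of phenyl for 1-hydroxyhexyl on this aromatic carbon gives a 3.1-fold lower number from compound 2 to compound 3 (0.49 log units; beyond the scatter) and so moves the number beyond the scatter, which the 1-hydroxypentyl of compound 1 did not do against the same phenyl. Within the data shown here, an aromatic ring at this place is therefore not required for the lowest number of the series so far, since the open chain of compound 3 holds that place with no ring at all. Chain length also counts here: the single extra carbon at the chain end gives a 5.4-fold lower number from compound 1 to compound 3 (0.73 log units; beyond the scatter) and is the largest step among the three compounds, although it rests on one pair only, and nothing at hand accounts for the size of this step.

Going by these compounds, two chain lengths fix no trend, so it stays open whether a 1-hydroxyheptyl or a longer chain lowers the number further or reverses the step. Also open, on these data alone, is what the oxygen contributes, a question that a plain hexyl chain, a ketone carbonyl or an ether at the same carbon would address, along with the separate behaviour of the two mirror-image forms of the hydroxyl-bearing carbon.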